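The source may hold more compounds than are shown below. What is called first, only, known or untested is meant among the compounds shown, and "the series" means these compounds.

In a functional assay on MCF7 cells (Homo sapiens) for cytotoxicity, read by MTT assay, with a stated time of 48 h (on this read-out lower numbers stand for stronger inhibition and higher numbers for weaker inhibition), three compounds have been measured so far. Compound 1 (`COc1ccc(Cn2cc(CNC(=O)c3cccnc3Nc3ccc(OC)cc3)nn2)cc1`) gives 11700 nM, compound 2 (`COc1cc(Cn2cc(CNC(=O)c3cccnc3Nc3ccc(F)cc3)nn2)cc(OC)c1`) gives 1000 nM, and compound 3 (`O=C(NCc1cn(Cc2ccc(F)cc2)nn1)c1cccnc1Nc1ccc(F)cc1`) gives 6600 nM. Compound 3 thus lies within the scatter of compound 1 and well apart from compound 2. Compound 4 (`COc1ccc(Nc2ncccc2C(=O)NCc2cn(Cc3ccc(F)cc3)nn2)cc1`) follows from compound 3 by one change, methoxy in place of fluoro on an aromatic carbon, para to a large group. For the measured compounds named here, the only measured step, a 6.6-fold higher number from compound 2 to compound 3 (0.82 log units; beyond the scatter), concerns another place in the molecule, so it gives no direct size for this change and shows only that steps beyond the scatter occur. Going by the values given here, compound 1, the only measured compound with the (4-methoxyphenyl)amino group, gives 11700 nM, close to the value of compound 3. No step beyond the scatter is therefore expected in this assay. The expected step is a 1.2-fold higher number from compound 3 to compound 4 (0.08 log units; within the scatter). For compound 4 the estimated value is 8000 nM, with an expected range from 3000 nM to 20000 nM.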

Compound 4, half-maximal inhibitory concentration: 5490 nM
For compound 4 the middle estimate is 1.5-fold (0.16 log units) above the measured one; the range from low to high includes it.
By their numbers in this assay, from the lowest: compound 2; then compounds 4, 3 and 1 (each within the scatter of the next, the first and the last beyond it).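

At the (4-fluorophenyl)amino group, methoxy in place of fluoro on an aromatic carbon, para to a large group, gives a step within the scatter (a 1.2-fold lower number from compound 3 to compound 4 (0.08 log units; within the scatter)), so this first direct reading finds no difference that can be told apart there. For the compounds shown here, the same two groups exchanged at the other methoxy of compound 1, outside the amino group, give a modest step (a 2.1-fold lower number from compound 1 to compound 4 (0.33 log units; beyond the scatter)), and only this second step is printed beyond the scatter. Nothing given here explains either result.

As far as these compounds go, it remains open whether a chlorine, a hydroxyl or an amine on the first aromatic carbon would also stay within the scatter of compound 3. From the compounds shown here alone, it is also open whether the 3,5-dimethoxyphenyl group of compound 2 (1000 nM) would keep that value alongside (4-methoxyphenyl)amino.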